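From an Acid Chain to a Sulfonamide on a Shared Core

The source may hold more compounds than are shown below. What is called first, only, known or untested is meant among the compounds shown, and "the series" means these compounds.

Of the compounds shown here, three on a shared core have been measured in a physicochemical assay for lipophilicity, read by HPLC, at pH 7.5; a higher number here means a more lipophilic compound, a lower number a more polar compound. Compound 1 `CC[C@@H](Nc1c(C#N)c(-c2ccc(-c3cccc(Cl)c3F)cc2)nc2cnccc12)C(N)=O` gives 3.1 in this assay. Compound 3 `CN(CC(N)=O)c1c(C#N)c(-c2ccc(Br)cc2)nc2cnccc12` gives 2.1 in this assay. Compound 2 `CCOc1ccccc1-c1ccc(-c2nc3cnccc3c(C[C@H](C)C(=O)O)c2C#N)cc1` gives 2.2 in this assay, the second highest of the three numbers; its nearest neighbour is compound 3, whose number lies within the scatter of it, and its furthest is compound 1, whose number lies beyond the scatter above it. Within the data shown here, no two of the measured compounds differ in a single place, so no measured step within this set is available.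

Compound 4 `CCOc1ccccc1-c1ccc(-c2nc3cnccc3c(NC(CC)CNS(=O)(=O)C3CC3)c2C#N)cc1` has not yet been measured. It differs from compound 2 as follows: a group of 12 heavy atoms (7 carbon, 2 nitrogen, 2 oxygen, 1 sulfur; one three-membered non-aromatic ring of carbon only) in place of a group of 6 heavy atoms (4 carbon, 2 oxygen; no ring), on an aromatic carbon, with the 2-carboxypropyl group leaving and the larger group, which carries the three-membered ring, entering on the aromatic carbon ortho to the cyano group and opposite the ring nitrogen. The step is expected to run upward and beyond the scatter, to a number 1.40 log units higher from compound 2 to compound 4 (beyond the scatter). Compound 4 is therefore expected to give 3.6 in this assay, with a range from 3 to 4.2.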

Compound 4, distribution coefficient: 3.6
Estimate against measurement, compound 4: no gap at the digits printed, within the range that was stated.
By their numbers in this assay, from the lowest: compounds 3 and 2 (each within the scatter of the next); then compound 1; then compound 4.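

Among these compounds, this is the first step read at this place on the shared core, the aromatic carbon ortho to a cyano group and opposite the ring nitrogen. In this assay, replacing the 2-carboxypropyl group with the larger group that carries the three-membered ring gives a number 1.40 log units higher from compound 2 to compound 4 (beyond the scatter), so the reading at this place moves well beyond the scatter, even though the entering group has more hydrogen-bond donors and acceptors than the group it replaces. No measurement shown here explains this rise. The exchange alters the whole group at once, so the compounds shown do not separate the contributions of the three-membered ring, the sulfonamide and the chain. As far as these compounds go, it remains open whether a methylsulfonamide or a carboxylic acid on the same amine-linked chain would give a similar number.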